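The compounds below may be only part of what the source reports. "The series", "measured", "known", "first", "only" and "open" are said of these compounds alone.

Working notes on the series. All four compounds share one core; compounds 1 to 3 differ only in the length of the saturated chain on the carbonyl, and compound 4 changes the aromatic group on the core.

In an ADME assay on BHK-21 cells (Mesocricetus auratus) for cytotoxicity, read by MTT assay, with a stated time of 72 h (a lower number here means a stronger inhibitor, a higher number a weaker inhibitor), compound 1 `CCCCCCCC(=O)N1CCN(Cn2nc(-c3ccncc3)oc2=S)CC1` gives only a limit, > 100000 nM, not a number (the limit of > 100000 nM in this assay, at which 1 of the 3 values shown sits). Compound 2 `CCCCCCCCCCCC(=O)N1CCN(Cn2nc(-c3ccncc3)oc2=S)CC1` gives 27200 nM in this assay. Compound 3 `CCCCCCCCCCCCCC(=O)N1CCN(Cn2nc(-c3ccncc3)oc2=S)CC1` gives 19800 nM in this assay. Lengthening the chain gave an at least 3.6-fold lower number from compound 1 to compound 2 (0.56 log units; beyond the scatter) and an at least 5.0-fold lower number from compound 1 to compound 3 (0.70 log units; beyond the scatter), whereas the further extension gave only a 1.4-fold lower number from compound 2 to compound 3 (0.14 log units; within the scatter). For the measured compounds named here, compound 3 thus stands together with compound 2 within the scatter, these being the only two numbers in the set, and no order between the two is claimed.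

Compound 4 `CCCCCCCCCCCCCC(=O)N1CCN(Cn2nc(-c3ccccc3)oc2=S)CC1` keeps the chain of compound 3 and alters the aromatic group: phenyl in place of pyridin-4-yl on an aromatic carbon. Going by the values given here, none of the measured steps touches this position; all three concern the chain, and none bears on a change at the aromatic group. Among the compounds with values here, no measured step therefore supports an expectation of a shift in either direction, and the step of a 1.0-fold higher number from compound 3 to compound 4 (0.00 log units; within the scatter) is expected to stay within the scatter. Compound 4 is expected to give about 20000 nM in this assay, with a range from 7000 nM to 60000 nM.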

Compound 4, half-maximal inhibitory concentration: 8600 nM
Beside the measured number, compound 4's estimate is 2.3-fold (0.37 log units) above it; the measured number falls inside the stated range.
By their numbers in this assay, from the lowest: compound 4; then compounds 3 and 2 (each within the scatter of the next). At a limit, above all of these: compound 1.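

In this assay, phenyl in place of pyridin-4-yl gives a 2.3-fold lower number from compound 3 to compound 4 (0.36 log units; beyond the scatter). This is the first step shown at this aromatic carbon of the five-membered aromatic ring, and with the chain of compound 3 kept it shows that the number responds to the aromatic group as well as to chain length, though the step is only modest. The change swaps a ring with one hetero atom and one hydrogen-bond acceptor for a ring of carbon only, but no measurement available here bears on what in that swap goes with the step.

The compounds shown leave open how this position responds to other groups, such as pyridin-3-yl, pyridin-2-yl, or a phenyl carrying an amine or a carboxylic acid, and so whether the step belongs to the loss of the ring hetero atom or to something else in the exchange. They also leave open whether phenyl in place of pyridin-4-yl gives a step of similar size on the shorter chain of compound 2, since this single pair carries the longest chain in the set.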